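Dropping the trifluoromethyl group from compound 3

The source may report more compounds than this note shows. Statements on the series, on what has been measured and on what is new or still open speak of the compounds shown alone.

In a functional assay on MDA-MB-435 cells (Homo sapiens) for cytotoxicity, read by MTT assay, with a stated time of 72 h (a higher number here means a weaker inhibitor, a lower number a stronger inhibitor), three compounds have been measured
- compound 1 `N[C@H]1CC[C@H](Nc2c(C(=O)NCc3ccc(Cl)cc3)nc(Br)c3cccnc23)CC1` gives 1000 nM
- compound 2 `N[C@H]1CC[C@H](Nc2c(C(=O)NCc3ccccn3)nc(Br)c3cccnc23)CC1` gives 4000 nM
- compound 3 `N[C@H]1CC[C@H](Nc2c(C(=O)NCc3cccc(C(F)(F)F)c3)nc(Br)c3cccnc23)CC1` gives 4200 nM

Compound 3 stands level with compound 2 within the scatter, and its number lies clearly above that of compound 1. Compound 4 `N[C@H]1CC[C@H](Nc2c(C(=O)NCc3ccccc3)nc(Br)c3cccnc23)CC1` has hydrogen in place of trifluoromethyl on an aromatic carbon, meta to a large group (hydrogen in place of trifluoromethyl on an aromatic carbon). Among the measured compounds shown here, no measured step makes this exact change. The nearest are swaps of the whole ring group: a 4.0-fold higher number from compound 1 to compound 2 (0.60 log units; beyond the scatter) and a 4.2-fold higher number from compound 1 to compound 3 (0.62 log units; beyond the scatter) and a 1.1-fold higher number from compound 2 to compound 3 (0.02 log units; within the scatter) as the smallest. These only suggest a likely size. In this assay the expected step is a 1.7-fold lower number from compound 3 to compound 4 (0.23 log units; within the scatter) and it should be small, toward a lower number, and possibly within the scatter. For compound 4 the estimated value is 2500 nM with an expected range from 900 nM to 6000 nM.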

Compound 4, half-maximal inhibitory concentration: 7000 nM
Estimate against measurement, compound 4: 2.8-fold (0.45 log units) below; measured number above the stated range.
By their numbers in this assay, from the lowest: compound 1; then compounds 2, 3 and 4 (each within the scatter of the next).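

In this assay, hydrogen in place of trifluoromethyl gives a 1.7-fold higher number from compound 3 to compound 4 (0.22 log units; within the scatter), so the trifluoromethyl group makes no difference beyond the scatter at this position. The unsubstituted phenyl also stays level with the pyridin-2-yl group, with a 1.8-fold higher number from compound 2 to compound 4 (0.24 log units; within the scatter), whereas hydrogen in place of chloro gives a 7.0-fold higher number from compound 1 to compound 4 (0.85 log units; beyond the scatter), which sets compound 1 apart from compound 4. No measurement shown explains this difference. Going by these compounds, it remains open whether bromo or methoxy in place of chloro would also give a number as low as that of compound 1.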